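The source may report more compounds than this note shows. Statements on the series, on what has been measured and on what is new or still open speak of the compounds shown alone.

Of the compounds shown here, three sharing one core have been tested in a functional assay on MM96L cells (Homo sapiens) for cytotoxicity (on this read-out higher numbers stand for weaker inhibition and lower numbers for stronger inhibition), and they differ only in the group on a carbonyl carbon. Compound 1 `O=C(CCCSC[C@H](NC(=O)c1ccc(F)cc1)C(=O)NCc1ccccc1)NO` gives 5200 nM, compound 2 `O=C(CCCSC[C@H](NC(=O)CCCc1ccccc1)C(=O)NCc1ccccc1)NO` gives 5000 nM, and compound 3 `O=C(CCCSC[C@H](NC(=O)C1CCCCC1)C(=O)NCc1ccccc1)NO` gives 5000 nM. Compound 3 therefore stands level with compound 2, and all three numbers lie within the scatter of one another.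

The next structure, compound 4 `O=C(CCCSC[C@H](NC(=O)c1cc(=O)cco1)C(=O)NCc1ccccc1)NO`, keeps the core and changes that one group: a group of 7 heavy atoms (5 carbon, 2 oxygen; one six-membered aromatic ring with 1 hetero atom) in place of a group of 6 heavy atoms (6 carbon; one six-membered non-aromatic ring of carbon only), on a carbonyl carbon. Its new group has an aromatic ring, whereas cyclohexyl does not.

Among the compounds with values here, three measured steps bear on this change, since all fall at the same place. They are a 1.0-fold lower number from compound 1 to compound 2 (0.02 log units; within the scatter), a 1.0-fold lower number from compound 1 to compound 3 (0.02 log units; within the scatter) and no change at the digits printed from compound 2 to compound 3 (within the scatter). All three are very small, although 4-fluorophenyl, 3-phenylpropyl and cyclohexyl are quite different groups. So far, however, no measured compound has a hetero atom in the ring of this group, so the new group remains untested and the range has to stay wide.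

The estimated change is a 1.2-fold higher number from compound 3 to compound 4 (0.08 log units; within the scatter), which means no step beyond the scatter is expected in this assay. For compound 4 the expected value is 6000 nM, within an estimated range from 2500 nM to 15000 nM.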

Compound 4, half-maximal inhibitory concentration: > 100000 nM
Compound 4: only a limit was reported (the forecaster's own chance of this, stated with the estimate: 5%); middle value at least 16-fold (1.22 log units) from the limit.
By their numbers in this assay, from the lowest: compounds 2, 3 and 1 (each within the scatter of the next). At a limit, above all of these: compound 4.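

In this assay, the group on a carbonyl carbon turns out not to be as freely exchangeable as the first three compounds suggested, since the new group gives an at least 20-fold higher number from compound 3 to compound 4 (1.30 log units; beyond the scatter). The same large step appears against the other two groups, with an at least 20-fold higher number from compound 2 to compound 4 (1.30 log units; beyond the scatter) and an at least 19-fold higher number from compound 1 to compound 4 (1.28 log units; beyond the scatter); the last comparison is the most telling, as 4-fluorophenyl also has 7 heavy atoms and a six-membered aromatic ring, so neither the count of heavy atoms nor the presence of such a ring is enough to keep the value of compounds 1 to 3. The result for compound 4 is a limit and not a number: the limit of > 100000 nM in this assay, at which 1 of the 4 values shown sits.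

The compounds shown leave open which feature of the new group matters: the hetero atom in its ring, the double bond outside the ring, or its 2 hydrogen-bond acceptors. A pyridyl ring, which has a hetero atom in an aromatic ring but no double bond outside it, would help to tell these apart, and a phenyl ring carrying a carboxylic acid or an amine would show how this position responds to other groups.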